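Changing the Aryl Ether Group: Expectation for Compound 4

The compounds below may be only part of what the source reports. "The series", "measured", "known", "first", "only" and "open" are said of these compounds alone.

Three compounds have been measured in a functional assay (aorta) with Oryctolagus cuniculus as the target; on this read-out lower numbers stand for tighter binding and higher numbers for weaker binding:

compound 1, `COc1cc(C(C)=O)ccc1OCCCN1CCC(C(c2ccc(F)cc2)c2ccc(F)c(F)c2)CC1`: 1.26 nM
compound 2, `COc1cc(C(C)=O)ccc1OCCCN1CCC(C(c2ccc(F)c(F)c2)c2ccc(F)c(F)c2)CC1`: 2.51 nM
compound 3, `CCc1ccc(OCCCN2CCC(C(c3ccc(F)cc3)c3ccc(F)cc3)CC2)c(OC)c1`: 2.51 nM

Compound 3 stands level with compound 2 at the digits shown, and the two together give the highest numbers of the three; the number for compound 1 differs from that of compound 3 by a gap that is within the scatter. Among the measured compounds shown here, the only step between measured compounds that differ in one place is a 2.0-fold higher number from compound 1 to compound 2 (0.30 log units; within the scatter), fluoro in place of hydrogen on an aromatic carbon, and it stays within the scatter.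

Compound 4, `Fc1ccc(C(c2ccc(F)cc2)C2CCN(CCCOc3ccc(Cl)cc3)CC2)cc1`, departs from compound 3 at a different part of the molecule: 4-chlorophenyl in place of 4-ethyl-2-methoxyphenyl on an oxygen on a saturated carbon. For the measured compounds named here, none of the measured steps alters the group on the ether oxygen, so no measured step bears directly on this change; all three measured compounds keep a 4-ethyl-2-methoxyphenyl or closely related group there, and the data say nothing about what its loss costs. The change is larger than the fluoro-for-hydrogen step and removes the one hydrogen-bond acceptor counted, so a somewhat weaker result is expected, with wide uncertainty. Compound 4 is therefore estimated at 6.3 nM in this assay, with a range of 1.6 nM to 32 nM. The expected step is a 2.5-fold higher number from compound 3 to compound 4 (0.40 log units; beyond the scatter).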

Compound 4, dissociation constant: 2 nM
For compound 4 the middle estimate is 3.2-fold (0.50 log units) above the measured one, within the range that was stated.
By their numbers in this assay, from the lowest: compounds 1, 4, 2 and 3 (each within the scatter of the next).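

In this assay, the exchange at this position gives a 1.3-fold lower number from compound 3 to compound 4 (0.10 log units; within the scatter), a step within the scatter, so the read-out does not separate the two compounds. Among the compounds shown here, this is the first measured change to the group on the ether oxygen, and it shows that, for this pair, 4-chlorophenyl can replace 4-ethyl-2-methoxyphenyl on an oxygen on a saturated carbon without a change this read-out can resolve, even though the leaving group carries a hydrogen-bond acceptor and the entering group carries none, and the entering group has fewer heavy atoms. Nothing in the available evidence explains why the exchange leaves the read-out unresolved.

The exchange removes the ethyl, the methoxy and the hydrogen-bond acceptor and brings in the chlorine all in one step, so the part played by each remains unresolved, and a phenyl ring carrying only a methoxy or only an ethyl would be needed to separate them. On these data alone, it also remains open how far this position accepts other groups, such as an amine or a carboxylic acid on that ring in place of the chlorine.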